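This account rests on a few compounds, and the source may have more. Where it says the series, first, only, none or still open, it means among the compounds named here.

Measured in a functional assay on BT-474 cells (Homo sapiens) for cytotoxicity, with a stated time of 72 h; a lower number here means a stronger inhibitor, a higher number a weaker inhibitor:
- compound 1 `Oc1ccc(CNC2(c3ccccc3F)CCCC2)cc1CN1CCN(c2ccccc2)CC1`: 37800 nM
- compound 2 `CCN(CC)Cc1cc(CNC2(c3ccccc3F)CCCC2)ccc1O`: > 100000 nM

Compound 2 stands at the limit of > 100000 nM in this assay, at which 1 of the 2 values shown sits, which is a limit and not a number.

Compound 3 `Oc1ccc(CNC2(c3ccccc3F)CCCC2)cc1CN1CCCCC1` has piperidin-1-yl in place of diethylamino on a saturated chain carbon bound to an aromatic carbon. Among the measured compounds shown here, no measured pair of compounds differing in one place is available to size this swap, so any forecast is rough. A modest step towards stronger inhibition in this assay is expected, and it may not exceed the scatter. For the measured compounds named here, the one firm number, compound 1 at 37800 nM, suggests that a weak but measurable result is plausible. The expected change is an at least 1.6-fold lower number from compound 2 to compound 3 (0.22 log units; that floor lies within the scatter). The estimated value for compound 3 is 60000 nM, with an expected range of 25000 nM to 100000 nM.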

Compound 3, half-maximal inhibitory concentration: 35600 nM
The estimate for compound 3 lay 1.7-fold (0.23 log units) above the measured number; the measured number falls inside the stated range.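

In this assay, putting piperidin-1-yl in place of diethylamino on this saturated chain carbon gives an at least 2.8-fold lower number from compound 2 to compound 3 (0.44 log units; beyond the scatter). That step is only a floor and not an exact size, since compound 2 carries a limit and not a number: the limit of > 100000 nM in this assay, at which 1 of the 3 values shown sits. The earlier compounds shown here offered no measured pair for this place, and this pair now shows that changing this one group can shift the result, although compound 3, at 35600 nM, remains a weak inhibitor.

Still open, as far as these compounds go, is whether other groups in this place, such as morpholin-4-yl or a simple primary amine, would lower the number further or raise it again. From the compounds shown here alone, the true size of the step also stays unknown, as does whether any group here could bring the series into a much stronger range.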